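The source may hold more compounds than are shown below. What is called first, only, known or untested is meant among the compounds shown, and "the series" means these compounds.

Working notes on the series. In an ADME assay on BJ cells (Homo sapiens) for cytotoxicity, with a stated time of 72 h (on this read-out higher numbers stand for an effect only at larger amounts of compound and lower numbers for an effect already at smaller amounts), compound 1 (`C=C[C@@](C)(/C=C/c1ccc(O)c(/C=C(\C)C(=O)OCC)c1)CCC=C(C)C`) gives > 36600 nM as a limit and not a number. Compound 2 (`CCOC(=O)/C=C/c1cc(/C=C/[C@](C)(/C=C/c2ccc(OC)cc2)CCC=C(C)C)ccc1O`) gives > 36600 nM as a limit too. Compound 3 (`CCOC(=O)/C(C)=C/c1cc(/C=C/[C@](C)(/C=C/c2ccc(OC)cc2)CCC=C(C)C)ccc1O`) likewise gives > 36600 nM as a limit, so it has no numeric value to start from. Within the data shown here, the series so far stands at one place, (the limit of > 36600 nM in this assay, at which 3 of the 3 values shown sit), and nothing in it separates the compounds.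

The move to compound 4 (`COc1ccc(/C=C/[C@@](C)(/C=C/c2ccc(O)c(/C=C/C(C)=O)c2)CCC=C(C)C)cc1`) is 2-acetylethenyl in place of 2-(ethoxycarbonyl)prop-1-en-1-yl on an aromatic carbon, with the new group on the same aromatic carbon, ortho to a hydroxy group. The measured step closest to this is a step that the two limits leave unreadable from compound 2 to compound 3, since it also exchanges the group at this aromatic carbon. The other, a step that the two limits leave unreadable from compound 1 to compound 3, concerns the vinyl on the saturated chain carbon and bears on this place less directly. Neither has a readable size, so they offer only the observation that no change so far has brought a number out of this assay in either direction.

No step beyond the scatter is therefore expected, and the estimated step is a number no higher from compound 3 to compound 4 (the limit leaves the size open) with a shift to smaller amounts left open. For compound 4 the estimate is 36600 nM with an expected range from 12000 nM to 80000 nM and another limit is the likelier report.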

Compound 4, half-maximal effective concentration: 12300 nM
Estimate against measurement, compound 4: 3.0-fold (0.47 log units) above; measured number inside the range.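

Among these compounds, the exchange of 2-(ethoxycarbonyl)prop-1-en-1-yl for 2-acetylethenyl on the aromatic carbon ortho to a hydroxy group gives an at least 2.9-fold lower number from compound 3 to compound 4 (0.47 log units; beyond the scatter) in this assay, the first readable step, while the earlier steps among compounds 1, 2 and 3 cannot be read. The narrower change of methyl in place of ethoxy on a carbonyl carbon gives an at least 2.9-fold lower number from compound 2 to compound 4 (0.47 log units; beyond the scatter), so this single exchange at the carbonyl carbon is enough to bring a number out of this assay for this pair, with no change needed elsewhere on the core. Compound 4 is so far the only compound with a number, and the three compounds carrying ethoxy on that carbonyl carbon all stay at a limit and not a number: the limit of > 36600 nM in this assay, at which 3 of the 4 values shown sit.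

On these data alone, the true size of both new steps stays open, as each starts from a limit and one compound with a number gives no trend. Also open, as far as these compounds go, is whether an ethyl, an amine or a carboxylic acid on this carbonyl carbon would give a number in this assay near that of compound 4 or return to the limit.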